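Carbamate substituent change on a ghrelin receptor agonist series

A few compounds are considered here, and "the series" means these few. Any claim that something is new, unique, unknown or untested is made for them only; others in the source may bear on it.

Measured compounds:
compound 1, `CN(CCCCO)C(=O)OCCn1nnnc1[C@@H](COCc1ccccc1)NC(=O)C(C)(C)N`: 3.8 nM
compound 2, `CC1(O)CCN(C(=O)OCCn2nnnc2[C@@H](COCc2ccccc2)NC(=O)C(C)(C)N)C1`: 10.1 nM

Both compounds were tested in a functional assay on H4 cells with growth hormone secretagogue receptor type 1 (Homo sapiens) as the target, read by FLIPR; on this read-out higher numbers stand for an effect only at larger amounts of compound and lower numbers for an effect already at smaller amounts. Compound 2 gives the highest number of the two; its nearest neighbour is compound 1, reached by a 2.7-fold higher number from compound 1 to compound 2 (0.42 log units; beyond the scatter), a modest change that lies beyond the scatter and goes with the swap of the open (4-hydroxybutyl)(methyl)amino group for the ring-closed 3-hydroxy-3-methylpyrrolidin-1-yl group on the carbonyl carbon.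

Compound 3, `CC(=O)NCCCCNC(=O)OCCn1nnnc1[C@@H](COCc1ccccc1)NC(=O)C(C)(C)N`, is not yet measured. It differs from compound 2 by (4-acetamidobutyl)amino in place of 3-hydroxy-3-methylpyrrolidin-1-yl on a carbonyl carbon. The entering group is again an open chain with no ring, which brings compound 3 closer in shape to compound 1 than to compound 2. Going by the values given here, the only step that bears on this change is the one from compound 1 to compound 2, and it was modest. The reverse of it is therefore the expectation here: a small move toward lower numbers in this assay, at the edge of the scatter, which is what a 1.8-fold lower number from compound 2 to compound 3 (0.26 log units; within the scatter) means. Compound 3 is estimated at 5.5 nM, with a range from 1.8 nM to 17 nM.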

Compound 3, half-maximal effective concentration: 82.5 nM
Compound 3: the middle estimate sits 15-fold (1.18 log units) below what was measured; the whole stated range lies below it.
By their numbers in this assay, from the lowest: compound 1; then compound 2; then compound 3.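

The result shows that having an open chain on this carbonyl carbon does not by itself keep the number low. In this assay, the two open-chain compounds lie furthest apart, with a 22-fold higher number from compound 1 to compound 3 (1.34 log units; beyond the scatter), while the ring-bearing compound 2 falls between them, and the change from its ring to the (4-acetamidobutyl)amino chain gives an 8.2-fold higher number from compound 2 to compound 3 (0.91 log units; beyond the scatter). Ring versus open chain therefore does not set the order of these three compounds, as the details of the chain also go with a large difference in the number, and nothing available explains why.

The compounds shown leave open which part of the change from compound 1 to compound 3 goes with the higher number: the acetamide in place of the hydroxyl at the chain end, or the hydrogen in place of the methyl on the chain nitrogen. A (4-hydroxybutyl)amino group or a (4-acetamidobutyl)(methyl)amino group at this place would pull those two changes apart, and a shorter chain with the same ends would show whether chain length matters here as well.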